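A few compounds are considered here, and "the series" means these few. Any claim that something is new, unique, unknown or untested is made for them only; others in the source may bear on it.

Compound 1 `Nc1cc(N)c2nc(-c3ccccc3)c(Oc3ccc(Cl)c(Cl)c3)nc2c1`: in a functional assay on OVCAR-8 cells (Homo sapiens) for inhibition, read by sulforhodamine B assay, with a stated time of 48 h (a higher number here means that more compound is tolerated, a lower number that less compound is tolerated), compound 1 gives < 100000 nM, which is a limit of the assay and not a number.
Compound 2 `CCOC(=O)[C@H](CCC(=O)O)NC(=O)c1ccc(CNc2nc3cc(N)cc(N)c3nc2-c2ccccc2)cc1`: in this assay compound 2 gives < 100000 nM, again only a limit.
Compound 3 `COc1ccc(CNc2nc3cc(N)cc(N)c3nc2-c2ccccc2)cc1`: in this assay compound 3 gives < 100000 nM, also a limit.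

Compound 1 therefore stands at no number of its own, and the same holds for the two other measured compounds, so the limit of < 100000 nM in this assay, at which 3 of the 3 values shown sit, is all that the measured set offers. Among the compounds with values here, no step between two measured compounds is available. The unmeasured compound 4 `Nc1cc(N)c2nc(-c3ccccc3)c(Sc3ccc(F)cc3)nc2c1` differs from compound 1 in one place: (4-fluorophenyl)sulfanyl in place of 3,4-dichlorophenoxy on an aromatic carbon. With every measured value sitting at a limit, no size or direction of step can be read from the data, and no change beyond the usual scatter is expected. Compound 4 is accordingly expected to give 30000 nM, in the range 5000 nM to 100000 nM, most likely again only as a limit. The implied step is estimated at a step that the limit leaves unreadable from compound 1 to compound 4.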

Compound 4, concentration lethal to 50% of the cells: 72400 nM
Compound 4: middle estimate off by 2.4-fold (0.38 log units), on the low side; low and high end bracket the measured number.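

The step between compound 1 and compound 4 cannot be read, because compound 1 gives only a limit: the limit of < 100000 nM in this assay, at which 3 of the 4 values shown sit.

The compounds shown leave open whether 3,4-dichlorophenoxy or (4-fluorophenyl)sulfanyl gives the lower value in this assay.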